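The compounds below may be only part of what the source reports. "The series", "measured", "known", "first", "only" and "open" are said of these compounds alone.

The measured compounds are: compound 1 `Cc1ccc2c(=O)c(CSC(=S)N3CCCCC3)coc2c1`, compound 2 `O=c1c(SC(=S)N2CCCCC2)coc2ccccc12` and compound 3 `Cc1ccc2c(=O)c(CSC(=S)N3CCCC3)coc2c1`.

In a functional assay on SW480 cells (Homo sapiens) for antiproliferative activity, read by MTT assay, with a stated time of 72 h (on this read-out lower numbers stand for stronger inhibition and higher numbers for weaker inhibition), compound 1 gives > 25000 nM, which is a limit of the assay and not a number. In this assay compound 2 gives 16300 nM. In this assay compound 3 gives 5900 nM. The change from compound 1 to compound 3 is pyrrolidin-1-yl in place of piperidin-1-yl on a thiocarbonyl carbon; it brought an at least 4.2-fold lower number from compound 1 to compound 3 (0.62 log units; beyond the scatter), a step whose size can only be bounded, since the starting value sits at the limit of > 25000 nM in this assay, at which 1 of the 3 values shown sits. Compound 4 `O=c1c(SC(=S)N2CCCC2)coc2ccccc12` has not yet been measured. It differs from compound 2 by pyrrolidin-1-yl in place of piperidin-1-yl on a thiocarbonyl carbon, the same change at the same place. The difference between the cores of compound 1 and compound 2 is not broken down here. For compound 4 a step of similar size is expected, a 4.1-fold lower number from compound 2 to compound 4 (0.61 log units; beyond the scatter), resting on an at least 4.2-fold lower number from compound 1 to compound 3 (0.62 log units; beyond the scatter). Compound 4 is therefore estimated at 4000 nM, expected to fall between 1500 nM and 12000 nM.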

Compound 4, half-maximal inhibitory concentration: > 25000 nM
Compound 4 was reported as a limit; the forecaster's own chance of this, stated with the estimate: 5%; middle value at least 6.2-fold (0.79 log units) from the limit.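

In this assay compound 4 gives > 25000 nM, which is a limit of the assay and not a number. Pyrrolidin-1-yl in place of piperidin-1-yl thus brought an at least 1.5-fold higher number from compound 2 to compound 4 (0.18 log units; that floor lies within the scatter), so the gain seen on the first core did not carry over to the second: the same change on two cores in this assay, an at least 4.2-fold lower number (0.62 log units; beyond the scatter) from compound 1 to compound 3 and an at least 1.5-fold higher number (0.18 log units; that floor lies within the scatter) from compound 2 to compound 4, at least 6.4-fold (0.81 log units) apart, beyond the scatter of two such steps This does not show the true size of either step, nor why the two cores part ways, since each step rests on a limit: the limit of > 25000 nM in this assay, at which 2 of the 4 values shown sit.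

The compounds shown leave open which part of the difference in core decides the outcome. They also leave open how morpholin-4-yl or an open-chain amine such as diethylamino, in place of piperidin-1-yl, would behave on either core.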